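Removing a Chloro Group: Expected Cytotoxicity of Compound 4

This account rests on a few compounds, and the source may have more. Where it says the series, first, only, none or still open, it means among the compounds named here.

Compound 1 `Cc1cc(/C=C/C#N)cc(C)c1Oc1nc(NCCn2ccc(=O)[nH]c2=O)ncc1Cl` was tested in an ADME assay on MT4 cells (Homo sapiens) for cytotoxicity, read by MTT assay, with a stated time of 5 days; on this read-out lower numbers stand for higher toxicity in this test and higher numbers for lower toxicity in this test. In this assay compound 1 reaches only the limit > 284000 nM. Compound 3 `Cc1cc(/C=C/C#N)cc(C)c1Oc1ccnc(NCCn2ccc(=O)[nH]c2=O)n1` carries the change (hydrogen in place of chloro on an aromatic carbon); in this assay compound 3 likewise reaches only the limit > 309000 nM. The step that the two limits leave unreadable from compound 1 to compound 3 therefore cannot be sized. Compound 2 `Cc1cc(C)cc(Oc2cc(Cl)nc(NCCn3ccc(=O)[nH]c3=O)n2)c1` has a core whose difference from compound 1 is not broken down here; in this assay compound 2 reaches only the limit > 56400 nM. Compound 4 `Cc1cc(C)cc(Oc2ccnc(NCCn3ccc(=O)[nH]c3=O)n2)c1` arises from compound 2 by hydrogen in place of chloro on an aromatic carbon, the same kind of change, though here the carbon is next to the ring nitrogen and meta to the 3,5-dimethylphenoxy group rather than ortho and para to a large group. The step that the limit leaves unreadable from compound 2 to compound 4 is expected to be small. This rests on compound 3, which in this assay reaches only the limit > 309000 nM. Compound 4 is therefore estimated at 150000 nM, most likely again only a limit.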

Compound 4, half-maximal cytotoxic concentration: 74800 nM
The estimate for compound 4 lay 2.0-fold (0.30 log units) above the measured number; the range from low to high includes it.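

No step can be read from compound 2 to compound 4: in this assay, compound 2 gives only a limit. The compounds shown leave open how far hydrogen in place of chloro shifts cytotoxicity, in this pair or between compound 1 and compound 3.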